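From chloro to methylsulfonyl on a shared core

The compounds below may be only part of what the source reports. "The series", "measured", "known", "first", "only" and "open" are said of these compounds alone.

Among the measured compounds shown here, in an ADME assay on microsomes from liver (Rattus norvegicus) for metabolic stability, read by LC-MS, using NADPH, with stated times of 6 min and 10 min, tested at 0.5 uM (on this read-out lower numbers stand for a less stable compound and higher numbers for a more stable compound), two compounds on a shared core have numbers so far. Compound 1 (`CC(=O)N1CCN(c2cc(-c3cc(Cl)c4c(N)ncnn34)ccc2C(F)(F)F)C(=O)C1(C)C`) shows 87% remaining and compound 2 (`CC(=O)N1CCN(c2cc(-c3cc(Cl)c4c(N)ncnn34)ccc2Cl)C(=O)C1(C)C`) shows 52% remaining, the lower of the two. Compound 3 (`CC(=O)N1CCN(c2cc(-c3cc(Cl)c4c(N)ncnn34)ccc2S(C)(=O)=O)C(=O)C1(C)C`) is still unmeasured. It differs from compound 2 by methylsulfonyl in place of chloro on an aromatic carbon. For the measured compounds named here, one measured step bears on this carbon: chloro in place of trifluoromethyl gave a number 35 percentage points lower from compound 1 to compound 2 (beyond the scatter) and that drop is large and beyond the scatter. The group at this carbon can therefore move the number a long way in this assay and chloro is the lower of the two groups tried. Methylsulfonyl itself has no measurement yet, so the step offers an analogy and no proof. A rise somewhat smaller than that earlier drop is expected, and the estimate reads a number 26 percentage points higher from compound 2 to compound 3 (beyond the scatter) as the likely change. For compound 3 the expected value is 78% within an estimated range of 58% to 95% of the compound remaining.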

Compound 3, percent of the compound remaining: 100%
Compound 3: the middle estimate sits 22 percentage points below what was measured, and the stated range ends below it.
By their numbers in this assay, from the lowest: compound 2; then compound 1; then compound 3.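

In this assay, this carbon now holds three groups, and methylsulfonyl in place of chloro gives a number 48 percentage points higher from compound 2 to compound 3 (beyond the scatter) on the shared core. The new group also outdoes the best earlier one, with a number 13 percentage points higher from compound 1 to compound 3 (beyond the scatter) when methylsulfonyl replaces trifluoromethyl, so the number reached by compound 1 was not the ceiling for this position and chloro stands lowest of the three. Compound 3 gives 100% and so sits at the very top of this read-out, which leaves no room to see any further gain, and nothing available explains why the groups fall in this order.

As far as these compounds go, whether the high numbers extend to other groups at this carbon stays open: a nitrile, an amine, a carboxylic acid or a longer chain on the sulfonyl, such as ethylsulfonyl, would each test how far the trend reaches. From the compounds shown here alone, these compounds also differ only at this one carbon, so it remains unknown whether the same order of groups would hold if the shared core were changed elsewhere.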